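Ring variation on the thiocarbonyl carbon: notes toward compound 3

The source may report more compounds than this note shows. Statements on the series, on what has been measured and on what is new or still open speak of the compounds shown alone.

Two members of the series have been measured. Compound 1 `Cc1cccc(/C(N)=N/NC(=S)N2CCCCC2)n1` gives 27% in a functional assay on HeLa cells (Homo sapiens) for cytotoxicity, read by MTT assay, with a stated time of 72 h, tested at 1 uM (a lower number here means less inhibition of growth, a higher number more inhibition of growth at the concentration tested), while compound 2 `Cc1cccc(/C(N)=N/NC(=S)N2CCCC2)n1` gives 8.7% in this assay. Among the compounds with values here, the only difference between them is the ring on the thiocarbonyl carbon, and the step of a number 18.3 percentage points lower from compound 1 to compound 2 (beyond the scatter) places compound 2 as the lowest of the two numbers so far, with compound 1 as its nearest neighbour, beyond the scatter.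

Compound 3 `Cc1cccc(/C(N)=N/NC(=S)N2CCSCC2)n1` continues from compound 2 with a further change at the same place: thiomorpholin-4-yl in place of pyrrolidin-1-yl on a thiocarbonyl carbon. Within the data shown here, only one measured step bears on this, the step from compound 1 to compound 2, which was modest in size. That step went from a six-membered ring to a five-membered one and lowered the number; compound 3 returns to a six-membered ring, now with a second hetero atom. Among the measured compounds shown here, no measured step tells what the added sulfur does, so the expectation rests on ring size alone.

Compound 3 is therefore expected to move back upward by a number 13.3 percentage points higher from compound 2 to compound 3 (beyond the scatter) in this assay, landing near the level of compound 1 but with wide uncertainty. The estimated value for compound 3 is 22%, between 6% and 38%.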

Compound 3, percent growth inhibition at one concentration: 46.5%
Estimate against measurement, compound 3: 24.5 percentage points below; the whole stated range lies below it.
By their numbers in this assay, from the lowest: compound 2; then compound 1; then compound 3.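

In this assay, within the data shown here, the exchange of pyrrolidin-1-yl for thiomorpholin-4-yl gives a number 37.8 percentage points higher from compound 2 to compound 3 (beyond the scatter) as a large step, so the substituent on the thiocarbonyl carbon spans a wider range of numbers than the first pair of compounds showed. Ring size alone does not settle the order: a number 19.5 percentage points higher from compound 1 to compound 3 (beyond the scatter) is the step between two six-membered non-aromatic rings, and the ring with the second hetero atom stands apart from piperidin-1-yl, giving the order compound 2, compound 1, compound 3 from the lowest number. The data at hand offer no measured explanation for the rise with this ring.

Going by these compounds, whether sulfur in particular matters, or any second hetero atom would do, remains open; morpholin-4-yl, with oxygen as the second hetero atom, and 4-methylpiperazin-1-yl, with a second nitrogen, would separate these two readings. Also open, on these data alone, is how the numbers behave for a ring larger than the six-membered ones, such as azepan-1-yl, and whether the order of the three compounds holds in any other assay.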